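A few compounds are considered here, and "the series" means these few. Any claim that something is new, unique, unknown or untested is made for them only; others in the source may bear on it.

Of the compounds shown here, three from one series have so far been tested in a functional assay on Huh-7 cells (Homo sapiens) for inhibition, read by sulforhodamine B assay, with a stated time of 72 h; on this read-out lower numbers stand for stronger inhibition and higher numbers for weaker inhibition. Compound 1 `CC(c1ccc(-c2ccccc2)c(F)c1)c1nnc2n1N=C(c1ccccc1)CS2` gives 6700 nM in this assay. Going by the values given here, compound 2 `CC(C)Cc1ccc(C(C)c2nnc3n2N=C(c2ccc(F)cc2)CS3)cc1` gives 7800 nM, a number within the scatter of the one for compound 1, so no order can be drawn between those two. Compound 3 `CC(c1ccc(-c2ccccc2)c(F)c1)c1n[nH]c(=S)n1N`, built differently from the other two, gives 43100 nM in this assay, beyond the scatter from both. Among the three numbers, compound 2 therefore holds the second highest, close to compound 1 and far from compound 3.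

Compound 4 `COc1ccc(C2=Nn3c(nnc3C(C)c3ccc(CC(C)C)cc3)SC2)cc1` has not yet been measured. It differs from compound 2 in one place: methoxy in place of fluoro on an aromatic carbon. Among the compounds with values here, no pair of measured compounds is separated by this same change, so nothing in the set shows how large such a step is. The step from compound 2 to compound 4 in this assay is expected to be small, a 1.0-fold lower number from compound 2 to compound 4 (0.02 log units; within the scatter), with no direction that exceeds the scatter. Compound 4 is accordingly estimated at 7500 nM, within a range from 3000 nM to 19000 nM.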

Compound 4, half-maximal inhibitory concentration: 3700 nM
For compound 4 the middle estimate is 2.0-fold (0.31 log units) above the measured one; the range from low to high includes it.
By their numbers in this assay, from the lowest: compounds 4, 1 and 2 (each within the scatter of the next, the first and the last beyond it); then compound 3.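

Compound 2 and compound 4 give the first measured size for a change at this position, on an aromatic carbon para to a large group: in this assay, going from 4-fluorophenyl to 4-methoxyphenyl gives a 2.1-fold lower number from compound 2 to compound 4 (0.32 log units; beyond the scatter). The position therefore accepts methoxy, with two heavy atoms and one hydrogen-bond acceptor, in place of fluoro, with one heavy atom and no acceptor, and the number falls modestly rather than rises. No measured evidence bears on what lies behind this step.

This single pair leaves open whether the same change would give a similar step on the other substituent pattern seen in compound 1. It also leaves open how an amine, a hydroxyl group or a longer chain such as ethoxy would read at this position.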